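A few compounds are considered here, and "the series" means these few. Any claim that something is new, unique, unknown or untested is made for them only; others in the source may bear on it.

Working notes on the series. Going by the values given here, the three measured members share one core and differ only on one aromatic carbon. Compound 1 `Cc1ccc(-c2cs/c(=N/NC(=O)CSc3nnnn3-c3ccccc3)n2-c2ccccc2)cc1` gives, in a functional assay on C6 cells (Rattus norvegicus) for cytotoxicity, read by MTT assay, with a stated time of 24 h, tested at 12 ug/mL (on this read-out higher numbers stand for a weaker effect at the one concentration tested and lower numbers for a stronger effect), 55.1%. Compound 2 `O=C(CSc1nnnn1-c1ccccc1)N/N=c1/scc(-c2ccccc2)n1-c1ccccc1` gives in this assay 47.1%, and compound 3 `O=C(CSc1nnnn1-c1ccccc1)N/N=c1/scc(-c2ccc(Cl)cc2)n1-c1ccccc1` gives in this assay 69.3%. Compound 1 thus sits between the other two: its gap to compound 2, a number 8 percentage points lower from compound 1 to compound 2 (within the scatter), is within the scatter, while its gap to compound 3, a number 14.2 percentage points higher from compound 1 to compound 3 (beyond the scatter), is beyond it; the remaining step, a number 22.2 percentage points higher from compound 2 to compound 3 (beyond the scatter), is also beyond the scatter.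

Compound 4 `Cc1ccc(-c2cs/c(=N/NC(=O)CSc3nnc(C)s3)n2-c2ccccc2)cc1` departs from compound 1 at a different place: 5-methyl-1,3,4-thiadiazol-2-yl in place of 1-phenyl-1H-tetrazol-5-yl on a sulfur. Among the compounds with values here, none of the measured steps touches this sulfur; all three concern the substituent on the aromatic carbon only. Within the data shown here, no measured step therefore bears on the change from compound 1 to compound 4, and no step beyond the scatter is expected in this assay from it, so the expected step of a number 0.1 percentage points lower from compound 1 to compound 4 (within the scatter) is put close to nil, with a wide range to reflect the absence of a precedent. Compound 4 is accordingly estimated in this assay at 55%, between 35% and 75%.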

Compound 4, a percentage reported as activity, at one concentration (the size of the read-out at that concentration, not a potency): 58.3%
Beside the measured number, compound 4's estimate is 3.3 percentage points below it; measured number inside the range.
By their numbers in this assay, from the lowest: compounds 2, 1 and 4 (each within the scatter of the next, the first and the last beyond it); then compound 3.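

Going by these compounds alone, at the sulfur, 5-methyl-1,3,4-thiadiazol-2-yl in place of 1-phenyl-1H-tetrazol-5-yl gives, in this assay, a number 3.2 percentage points higher from compound 1 to compound 4 (within the scatter), the first measured step at this place. The series thus shows that this read-out does not separate the two groups on this sulfur, even though the entering group has fewer heavy atoms, lacks the six-membered aromatic ring and carries a sulfur in its five-membered aromatic ring. Nothing available accounts for this result.

On these data alone, it remains open whether the same exchange on the sulfur also stays within the scatter with chloro or hydrogen in place of methyl on the aromatic carbon, as in compound 3 and compound 2. Also open, as far as these compounds go, is whether an aminoethyl group or a carboxymethyl group on this sulfur would give a step beyond the scatter.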